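The source may hold more compounds than are shown below. What is called first, only, known or untested is meant among the compounds shown, and "the series" means these compounds.

Working notes on the series. Compound 1 `Cc1cc(C)cc(-c2c(C)nn(-c3nc(-c4ccc(Cl)c(Cl)c4)c(SC(C)C)s3)c2C(=O)O)c1` gives 2700 nM in a functional assay on BJAB cells (Homo sapiens) for antiproliferative activity, with a stated time of 4 days; a lower number here means that less compound is needed, a higher number that more compound is needed for the effect. Compound 2 `Cc1nn(-c2nc(-c3ccc(Cl)c(Cl)c3)c(SC(C)C)s2)c(C(=O)O)c1-c1ccc(Cl)cc1` gives 2500 nM in this assay, which is a 1.1-fold lower number from compound 1 to compound 2 (0.03 log units; within the scatter). Compound 3 `COc1cccc(-c2c(C)nn(-c3nc(-c4ccc(Cl)c(Cl)c4)c(SC(C)C)s3)c2C(=O)O)c1` gives 14000 nM in this assay, the highest number of the three; it is reached by a 5.2-fold higher number from compound 1 to compound 3 (0.71 log units; beyond the scatter) and by a 5.6-fold higher number from compound 2 to compound 3 (0.75 log units; beyond the scatter), so the 3-methoxyphenyl compound stands apart from the other two beyond the scatter.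

Compound 4 `Cc1nn(-c2nc(-c3ccc(Cl)c(Cl)c3)c(SC(C)C)s2)c(C(=O)O)c1-c1ccncc1` has not yet been measured. It differs from compound 3 in pyridin-4-yl in place of 3-methoxyphenyl on an aromatic carbon. Among the compounds with values here, the two steps that touch this position are a 5.2-fold higher number from compound 1 to compound 3 (0.71 log units; beyond the scatter) and a 5.6-fold higher number from compound 2 to compound 3 (0.75 log units; beyond the scatter), both modest; no measured step exchanges a phenyl for a pyridinyl, so the direction for compound 4 is open. The number for compound 4 is expected to stay near that of its parent, with no change at the digits printed from compound 3 to compound 4 (within the scatter) as the central guess. Compound 4 is therefore estimated at 14000 nM in this assay, with a wide range from 4000 nM to 50000 nM.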

Compound 4, half-maximal effective concentration: 5900 nM
The estimate for compound 4 lay 2.4-fold (0.38 log units) above the measured number; the range from low to high includes it.
By their numbers in this assay, from the lowest: compounds 2 and 1 (each within the scatter of the next); then compound 4; then compound 3.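

In this assay the first ring with a hetero atom at this position gives a 2.4-fold lower number from compound 3 to compound 4 (0.38 log units; beyond the scatter) and also a 2.4-fold higher number from compound 2 to compound 4 (0.37 log units; beyond the scatter) as well as a 2.2-fold higher number from compound 1 to compound 4 (0.34 log units; beyond the scatter) so pyridin-4-yl falls in the middle of the measured range rather than at either end. On this aromatic carbon, a ring nitrogen is therefore compatible with a number lower than that of the 3-methoxyphenyl compound, though compounds 1 and 2 remain lower still. Nothing at hand accounts for this order of the four groups.

The compounds shown leave open whether the placement of the ring nitrogen matters, as a pyridin-3-yl or pyridin-2-yl group would test. They also leave open how an unsubstituted phenyl or a 4-aminophenyl group would compare at this position.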